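Hydrazone series: swapping the phenolic hydroxy for dimethylamino

The source may report more compounds than this note shows. Statements on the series, on what has been measured and on what is new or still open speak of the compounds shown alone.

Two members of this hydrazone series have been measured against an assay on isolated protein for inhibition of Amine oxidase [flavin-containing] A (Homo sapiens), read by spectrophotometry; on this read-out higher numbers stand for weaker inhibition and lower numbers for stronger inhibition. Compound 1 `Clc1ccc(/C=N/Nc2nc3ccccc3nc2Cc2ccccc2)cc1` gives 76 nM in this assay. For the measured compounds named here, compound 2 `Oc1ccc(/C=N/Nc2nc3ccccc3nc2Cc2ccccc2)cc1` gives 3.4 nM in this assay, and the single step between them, a 22-fold lower number from compound 1 to compound 2 (1.35 log units; beyond the scatter), is the only structural comparison so far. Going by the values given here, compound 2 thus holds the lowest of the two numbers on record, with compound 1 as its only neighbour.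

Compound 3 `CN(C)c1ccc(/C=N/Nc2nc3ccccc3nc2Cc2ccccc2)cc1` differs from compound 2 by one change: dimethylamino in place of hydroxy on an aromatic carbon. Among the compounds with values here, no measured step bears directly on this exchange; the one step available only shows that the group at this position matters, since replacing chloro with hydroxy moved the number a great deal. Dimethylamino keeps an acceptor but gives up the donor that hydroxy carried, so the expectation is that compound 3 will lose some, though not all, of the gain seen in compound 2. Compound 3 is therefore expected to show a step of a 2.9-fold higher number from compound 2 to compound 3 (0.47 log units; beyond the scatter) in this assay. Compound 3 is accordingly estimated at 10 nM in this assay, within a range from 2 nM to 50 nM.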

Compound 3, half-maximal inhibitory concentration: 83 nM
Beside the measured number, compound 3's estimate is 8.3-fold (0.92 log units) below it; the measured number lies above the stated range.
By their numbers in this assay, from the lowest: compound 2; then compounds 1 and 3 (each within the scatter of the next).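

In this assay, the exchange of hydroxy for dimethylamino gives a 24-fold higher number from compound 2 to compound 3 (1.39 log units; beyond the scatter), a step as large as the one that separated chloro from hydroxy, so dimethylamino keeps none of the gain seen with hydroxy. For the compounds shown here, the comparison with chloro gives a 1.1-fold higher number from compound 1 to compound 3 (0.04 log units; within the scatter), which places compound 3 level with compound 1 and leaves hydroxy as the only one of the three groups at this position with a clearly lower number. Hydroxy counts 1 hydrogen-bond donor and 1 hydrogen-bond acceptor, while dimethylamino counts 0 hydrogen-bond donors and 1 hydrogen-bond acceptor and has 3 heavy atoms in place of 1, but no measurement at hand explains the difference between compound 2 and compound 3.

On these data alone, what a methoxy or an amino group would give on this aromatic carbon stays open, and these would help show whether the low number of compound 2 depends on the hydroxy hydrogen or on the size of the group. As far as these compounds go, all three compounds share the same core, so whether hydroxy stands out in the same way on another core also remains open.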